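The source may report more compounds than this note shows. Statements on the series, on what has been measured and on what is new or still open speak of the compounds shown alone.

Compound 1 `CC(C)(C)OC(=O)NCc1ccc(NC(=O)CCc2cccc3c2B(O)OC3)cc1`: 4800 nM
Compound 2 `CC(C)c1cccc(NC(=O)CCc2cccc3c2B(O)OC3)c1`: 22000 nM

In an ADME assay on WI-38 cells (Homo sapiens) for cytotoxicity, read by MTT assay, with a stated time of 72 h (on this read-out lower numbers stand for stronger inhibition and higher numbers for weaker inhibition), compound 2 stands at 22000 nM, the higher of the two numbers, and compound 1 stands at 4800 nM, the lower of the two numbers. The gap between these two numbers lies beyond the scatter. Compound 3 `O=C(CCc1cccc2c1B(O)OC2)Nc1cccc(-c2cccc(Cl)c2)c1` awaits measurement. It carries 3-chlorophenyl in place of isopropyl on an aromatic carbon, meta to a large group: 3-chlorophenyl in place of isopropyl on an aromatic carbon. Going by the values given here, no measured pair differs in one place only, so no direct step is available as a guide. The expectation therefore leans only on compound 1 at 4800 nM, which shows that a lower number than that of compound 2 is reachable in this assay. A modest move towards a lower number, slightly beyond the scatter, is expected: a 2.4-fold lower number from compound 2 to compound 3 (0.39 log units; beyond the scatter). For compound 3 the estimated value is 9000 nM, with an expected range from 3000 nM to 27000 nM.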

Compound 3, half-maximal inhibitory concentration: 58000 nM
Compound 3: middle estimate off by 6.4-fold (0.81 log units), on the low side, and the stated range ends below it.
By their numbers in this assay, from the lowest: compound 1; then compound 2; then compound 3.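

In this assay, going by these compounds alone, the first direct step at this place is a 2.6-fold higher number from compound 2 to compound 3 (0.42 log units; beyond the scatter), so 3-chlorophenyl in place of isopropyl on an aromatic carbon, meta to a large group, raises the number rather than lowering it. Compound 1 differs from both compounds in more than one place, so it gives no direct guide to this position, and the larger group with its added aromatic ring did not bring a lower number here. Nothing measured here gives a reason for this step.

Going by these compounds, whether the rise follows the added ring or the chlorine stays open. Also open, on these data alone, is whether a plain phenyl, an amine or a carboxylic acid at this place would give a higher or a lower number.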